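The compounds below may be only part of what the source reports. "The series", "measured", "known", "first", "only" and "open" are said of these compounds alone.

Working notes on the series

Compound 1 `COc1ccccc1N1CCN(CCCCCCCn2ncc(N3CCN(C(=O)c4ccco4)CC3)c(Cl)c2=O)CC1` is the reference of the set. In an assay on cell membranes for binding affinity to Adrenergic receptor alpha-1 (Rattus norvegicus), read by radioligand binding (a higher number here means a weaker inhibitor, a lower number a stronger inhibitor), compound 1 gives 1.9 nM. Compound 2 `O=C(c1ccco1)N1CCN(c2cnn(CCCCCCCN3CCN(c4ccccc4Cl)CC3)c(=O)c2Cl)CC1` differs from compound 1 by chloro in place of methoxy on an aromatic carbon, and in this assay compound 2 gives 11.5 nM; the change costs a 6.1-fold higher number from compound 1 to compound 2 (0.78 log units; beyond the scatter). Compound 3 `COc1ccccc1N1CCN(CCCn2nc(N3CCN(C(=O)c4ccco4)CC3)ccc2=O)CC1` carries the same methoxyphenyl end as compound 1 but a different core and a shorter chain; how the two cores differ is not broken down here. In this assay compound 3 gives 64.5 nM, the highest number of the three measured compounds.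

Compound 4 `O=C(c1ccco1)N1CCN(c2ccc(=O)n(CCCN3CCN(c4ccccc4Cl)CC3)n2)CC1` has not yet been measured. It differs from compound 3 by chloro in place of methoxy on an aromatic carbon, which is the same change, at the same kind of place, as that from compound 1 to compound 2. Going by the values given here, with only one measured instance of the change, the expectation for compound 4 rests on that single step: compound 3 is expected to move by about a 5.4-fold higher number from compound 3 to compound 4 (0.73 log units; beyond the scatter), because the measured step of a 6.1-fold higher number from compound 1 to compound 2 (0.78 log units; beyond the scatter) went in that direction. Compound 4 is therefore expected to give about 350 nM in this assay, within an estimated range from 100 nM to 1200 nM.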

Compound 4, inhibition constant: 12.8 nM
Beside the measured number, compound 4's estimate is 27-fold (1.44 log units) above it; the measured number lies below the stated range.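

In this assay the change from 2-methoxyphenyl to 2-chlorophenyl gives a 5.0-fold lower number from compound 3 to compound 4 (0.70 log units; beyond the scatter), whereas the earlier pair moved the other way, a 6.1-fold higher number from compound 1 to compound 2 (0.78 log units; beyond the scatter). The size of the step is similar in the two pairs, but its direction is not, so the result on one core does not carry over to the other: the same change on two cores in this assay, a 6.1-fold higher number (0.78 log units; beyond the scatter) from compound 1 to compound 2 and a 5.0-fold lower number (0.70 log units; beyond the scatter) from compound 3 to compound 4, 30-fold (1.48 log units) apart, beyond the scatter of two such steps. What this does not show is which feature reverses the step, since the two pairs differ in both core and chain length, and one pair on each core cannot separate these or predict the change on any further core.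

Still open, as far as these compounds go, is whether the reversal follows the core or the chain, which the core of compound 1 with the shorter chain of compound 3, or the core of compound 3 with the longer chain of compound 1, could settle. Also open, from the compounds shown here alone, is how a fluoro or a methyl group in the same place would read on either core.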